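The source may hold more compounds than are shown below. What is called first, only, known or untested is meant among the compounds shown, and "the series" means these compounds.

In a functional assay on MGC-803 cells (Homo sapiens) for inhibition, read by CCK-8 assay, with a stated time of 48 h (a lower number here means a stronger inhibitor, a higher number a weaker inhibitor), compound 1 `COc1ccc(CN(C(=O)CSC(=S)N2CCN(C)CC2)c2cc(OC)c(OC)c(OC)c2)cc1` gives 1280 nM, and compound 2 `CCN1CCN(C(=S)SCC(=O)N(Cc2ccc(OC)cc2)c2cc(OC)c(OC)c(OC)c2)CC1` gives 9890 nM. Compound 3 `COc1ccc(CN(C(=O)CSC(=S)N2CCc3cc(Br)ccc32)c2cc(OC)c(OC)c(OC)c2)cc1` gives > 20000 nM, which is a limit of the assay and not a number. Compound 4 `COc1ccc(CN(C(=O)CSC(=S)N2CCc3ccccc3C2)c2cc(OC)c(OC)c(OC)c2)cc1` is still unmeasured, and it differs from compound 3 on a thiocarbonyl carbon: 1,2,3,4-tetrahydroisoquinolin-2-yl in place of 5-bromo-2,3-dihydro-1H-indol-1-yl on a thiocarbonyl carbon. Earlier changes at this carbon bear on it. Bringing in 5-bromo-2,3-dihydro-1H-indol-1-yl gave an at least 15-fold higher number from compound 1 to compound 3 (1.19 log units; beyond the scatter), and also an at least 2.0-fold higher number from compound 2 to compound 3 (0.30 log units; that floor lies within the scatter), a floor within the scatter. Both the leaving and entering groups hold a six-membered aromatic ring of carbon only, so the weak activity seen in an at least 15-fold higher number from compound 1 to compound 3 (1.19 log units; beyond the scatter) is expected to persist. The expected change is an at least 1.3-fold lower number from compound 3 to compound 4 (0.12 log units; that floor lies within the scatter), which is none beyond the scatter. For compound 4 the estimated value is 15000 nM, with an expected range of 4000 nM to 40000 nM.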

Compound 4, half-maximal inhibitory concentration: 5940 nM
The estimate for compound 4 lay 2.5-fold (0.40 log units) above the measured number; low and high end bracket the measured number.
By their numbers in this assay, from the lowest: compound 1; then compounds 4 and 2 (each within the scatter of the next). At a limit, above all of these: compound 3.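

A ring carrying a six-membered aromatic ring of carbon only does not by itself rule out activity on this thiocarbonyl carbon: the swap gives an at least 3.3-fold lower number from compound 3 to compound 4 (0.52 log units; beyond the scatter). Compound 3 stands at a limit of the assay, so that step is only a floor: the limit of > 20000 nM in this assay, at which 1 of the 4 values shown sits. Against 4-methylpiperazin-1-yl the new group gives a 4.6-fold higher number from compound 1 to compound 4 (0.67 log units; beyond the scatter), while against 4-ethylpiperazin-1-yl it gives a 1.7-fold lower number from compound 2 to compound 4 (0.22 log units; within the scatter).

The swap changes the non-aromatic ring and removes bromine together, so the shown compounds cannot separate these two changes. Unbrominated 2,3-dihydro-1H-indol-1-yl would address that, and how morpholin-4-yl behaves here remains open.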